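This account rests on a few compounds, and the source may have more. Where it says the series, first, only, none or still open, it means among the compounds named here.

Measured so far in an ADME assay on the whole organism with Oryza sativa as the target, tested at 10 uM; on this read-out lower numbers stand for a stronger effect and higher numbers for a weaker effect at the one concentration tested:
- compound 1, `C[C@H](NC(=O)Nc1ccccc1F)c1ccccc1`, giving 65%
- compound 2, `C[C@H](NC(=O)Nc1cccc(F)c1)c1ccccc1`, giving 88%
- compound 3, `C[C@@H](NC(=O)Nc1cccc(F)c1F)c1ccccc1`, giving 90%

Compound 3 carries the highest of the three numbers, which on this read-out is the weakest effect at the single concentration tested. Its nearest neighbour is compound 2, whose value sits within the usual scatter of compound 3, so the two cannot be ordered. Its furthest neighbour is compound 1, whose value lies beyond the scatter, so the gap between compound 1 and compound 3 is a real one. Within the data shown here, no pair among the three differs in a single place, so none of these gaps can be tied to one structural change.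

The next compound is compound 4, `C[C@H](NC(=O)Nc1cccc(F)c1F)c1ccccc1`. Relative to compound 3 the change is the two compounds have the same atoms and bonds and differ only in configuration as drawn: 1 of 1 stereo elements differ; a stereocentre at a saturated chain carbon is drawn R in compound 3 and S in compound 4. Among the measured compounds shown here, nothing measured here isolates such a change in configuration, so no measured step guides the expectation. In this assay a step of modest size is expected from compound 3 to compound 4, toward lower numbers, and it may well stay within the scatter: a number 15 percentage points lower from compound 3 to compound 4 (beyond the scatter). Compound 4 is estimated at 75%, with a range from 50% to 95%.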

Compound 4, a percentage reported as activity, at one concentration (the size of the read-out at that concentration, not a potency): 100%
Compound 4: middle estimate off by 25 percentage points, on the low side, outside the stated range (above it).
By their numbers in this assay, from the lowest: compound 1; then compounds 2, 3 and 4 (each within the scatter of the next, the first and the last beyond it).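

In this assay, the stereocentre at the saturated chain carbon can now be read on its own, and going from R to S gives a number 10 percentage points higher from compound 3 to compound 4 (within the scatter), a step that reflects configuration alone: the fact that compounds 3 and 4 differ only in the configuration as drawn

With the S configuration held, fluoro in place of hydrogen on an aromatic carbon gives a number 12 percentage points higher from compound 2 to compound 4 (beyond the scatter), while the same kind of replacement at a different aromatic carbon gives a number 35 percentage points higher from compound 1 to compound 4 (beyond the scatter). These two steps share an end point, yet one is modest and the other large, so this replacement does not have a single size in the series.

From the compounds shown here alone, it remains open whether inverting the stereocentre would also stay within the scatter with the fluoro pattern of compound 1 or compound 2. Going by these compounds, it is also open how a chloro or methoxy group on the aromatic ring, or a longer chain at the stereocentre, would read in this assay.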